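The compounds below may be only part of what the source reports. "The series", "measured", "known", "first", "only" and "open" are said of these compounds alone.

Measured in a functional assay on MCF7 cells (Homo sapiens) for antiproliferative activity, with a stated time of 5 days; a lower number here means a stronger inhibitor, a higher number a weaker inhibitor:
Compound 1 `CCCCc1ccc2[nH]c(-c3ccc(C)cc3)c(C=C(C#N)C#N)c2c1` gives 100 nM.
Compound 2 `CCCCc1ccc2[nH]c(-c3ccc(CC)cc3)c(C=C(C#N)C#N)c2c1` gives 200 nM.
Compound 3 `CCCCCc1ccc2[nH]c(-c3ccc(C(F)(F)F)cc3)c(C=C(C#N)C#N)c2c1` gives 100 nM.

Compound 1 and compound 2 differ by methyl in place of hydrogen on a saturated chain carbon bound to an aromatic carbon. This change gave a 2.0-fold higher number from compound 1 to compound 2 (0.30 log units; within the scatter). Compound 3 differs from compound 1 in more than one place; the difference between the two cores is not broken down here. In this assay compound 3 stands level with compound 1 at the digits recorded, and the two together hold the lowest numbers of the three, though the gap to compound 2 remains within the scatter.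

Compound 4 `CCCCCCc1ccc2[nH]c(-c3ccc(C(F)(F)F)cc3)c(C=C(C#N)C#N)c2c1` has not yet been measured. It differs from compound 3 by methyl in place of hydrogen on a saturated chain carbon, five bonds along the chain from an aromatic carbon. This is the same kind of change as that between compound 1 and compound 2, but not the same: there the entering methyl sits on a saturated chain carbon bound to an aromatic carbon, here on a saturated chain carbon, five bonds along the chain from an aromatic carbon. The step expected in this assay is a 1.3-fold higher number from compound 3 to compound 4 (0.11 log units; within the scatter), resting on the earlier step of a 2.0-fold higher number from compound 1 to compound 2 (0.30 log units; within the scatter), which stayed within the scatter. Compound 4 is accordingly estimated at 130 nM, with a range from 60 nM to 300 nM.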

Compound 4, half-maximal inhibitory concentration: 68 nM
Compound 4: middle estimate off by 1.9-fold (0.28 log units), on the high side, and the stated range covers the measured number.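

In this assay, methyl in place of hydrogen on a saturated chain carbon, five bonds along the chain from an aromatic carbon, gives a 1.5-fold lower number from compound 3 to compound 4 (0.17 log units; within the scatter), and this step does not match the earlier one: the same change on two cores in this assay, a 2.0-fold higher number (0.30 log units; within the scatter) from compound 1 to compound 2 and a 1.5-fold lower number (0.17 log units; within the scatter) from compound 3 to compound 4, 2.9-fold (0.47 log units) apart, beyond the scatter of two such steps. Each step on its own stays within the scatter, but the gap between them shows that the step read on the core of compound 1 did not carry over to the core of compound 3, in size or in direction. This rests on a single pair per core, and the methyl enters at a different place in each pair while the cores differ in more than one place, so it does not show which difference accounts for the gap or how the change would behave on any further core.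

The compounds shown leave open what a longer chain, or a chain carrying an amine or a carboxylic acid, would do to the number in this assay. They also leave open whether a methyl entering at the same place on both cores would give matching steps.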